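Methoxy for fluoro on a benzyl arm at the limit

The source may report more compounds than this note shows. Statements on the series, on what has been measured and on what is new or still open speak of the compounds shown alone.

The shared core of compound 2 `CCOC(=O)c1ccc(-c2nn(Cc3ccc(F)cc3)c3ccccc23)cc1` carries an ethyl ester at one end and a substituted benzyl group on an aromatic nitrogen at the other. In a functional assay on cells (Platelet, Homo sapiens) for inhibition (a lower number here means a stronger inhibitor, a higher number a weaker inhibitor), compound 2 gives only a limit, > 10000 nM. Compound 1 `CCOC(=O)c1ccc(-c2nn(Cc3cccc(Cl)c3)c3ccccc23)cc1` also gives only a limit in this assay, > 10000 nM. For the measured compounds named here, the single step between them, a step that the two limits leave unreadable from compound 1 to compound 2, therefore has no readable size. Both values sit at the limit of > 10000 nM in this assay, at which 2 of the 2 values shown sit.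

Compound 3 `CCOC(=O)c1ccc(-c2nn(Cc3ccc(OC)cc3)c3ccccc23)cc1` differs from compound 2 by methoxy in place of fluoro on an aromatic carbon. Going by the values given here, no measured step speaks to an exchange of this kind, and the only step at hand gives no size at all. Nothing in what has been measured points away from the limit, so the step from compound 2 to compound 3 is expected to be a step that the limit leaves unreadable from compound 2 to compound 3, that is, no change that could be read in this assay. Compound 3 is therefore estimated in this assay at 20000 nM, with a range from 6000 nM to 60000 nM, and most likely again only a limit will be reported.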

Compound 3, half-maximal inhibitory concentration: > 10000 nM
Compound 3 gave a limit, no number; the forecaster's own chance of this, stated with the estimate: 85%; the middle value does not contradict the limit.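

Compound 3 also gives only a limit in this assay, > 10000 nM, so no step among compound 1, compound 2 and compound 3 can be read: the limit of > 10000 nM in this assay, at which 3 of the 3 values shown sit.

The compounds shown leave open whether any change on the shared core, at the benzyl arm or at the ethyl ester, would give a readable value in this assay.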